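Compound 2 and a trichlorophenyl change on the oxygen

This account rests on a few compounds, and the source may have more. Where it says the series, first, only, none or still open, it means among the compounds named here.

In a functional assay on M21 cells (Homo sapiens) for antiproliferative activity, read by sulforhodamine B assay, with a stated time of 48 h (on this read-out higher numbers stand for weaker inhibition and lower numbers for stronger inhibition), compound 1 `CCCN1CCN(c2ccc(S(=O)(=O)Oc3ccccc3CC)cc2)C1=O` reports > 50000 nM, which is a limit and not a number. Among the measured compounds shown here, compound 2 `CCCN1CCN(c2ccc(S(=O)(=O)Oc3ccc(C)cc3C)cc2)C1=O` gives 9700 nM, the only true number so far. For the measured compounds named here, the one measured step is an at least 5.1-fold lower number from compound 1 to compound 2 (0.71 log units; beyond the scatter), with 2,4-dimethylphenyl in place of 2-ethylphenyl on an oxygen.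

Compound 3 `CCCN1CCN(c2ccc(S(=O)(=O)Oc3cc(Cl)c(Cl)cc3Cl)cc2)C1=O` alters that same place, the oxygen whose other neighbour is the sulfonyl sulfur, where 2,4,5-trichlorophenyl takes the place of 2,4-dimethylphenyl: 2,4,5-trichlorophenyl in place of 2,4-dimethylphenyl on an oxygen. Only the earlier step bears on this change. As far as these compounds go, it shows that this assay can respond to a change of this group, but its true size is unknown, as one end of it is a limit. Going by the values given here, no measured compound carries chlorine, so that step gives neither a size nor a direction for the new group. No shift beyond the scatter is therefore expected, and the expected step is a 1.2-fold lower number from compound 2 to compound 3 (0.08 log units; within the scatter). For compound 3 the estimated value is 8000 nM, with an expected range from 1800 nM to 35000 nM.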

Compound 3, half-maximal inhibitory concentration: 15000 nM
Estimate against measurement, compound 3: 1.9-fold (0.27 log units) below, and the stated range covers the measured number.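

At this place, the oxygen whose other neighbour is the sulfonyl sulfur, the first group carrying chlorine gives a 1.5-fold higher number from compound 2 to compound 3 (0.19 log units; within the scatter) in this assay, so 2,4,5-trichlorophenyl and 2,4-dimethylphenyl cannot be told apart here, even though the groups differ in their atoms. Set against 2-ethylphenyl, the same chlorinated group gives an at least 3.3-fold lower number from compound 1 to compound 3 (0.52 log units; beyond the scatter), so two groups of different make-up now stand apart from 2-ethylphenyl beyond the scatter, where before there was only one. Compound 1 has a limit and not a number, so the true size of each step that starts from it stays unread: the limit of > 50000 nM in this assay, at which 1 of the 3 values shown sits.

The three groups differ from one another in more than one substituent, so the compounds shown do not tell which substituent on the phenyl ring accounts for the separation from compound 1. As far as these compounds go, how a single chlorine, a methoxy group or a nitrile on that ring would read stays open, as do a pyridine in place of the phenyl ring and a change to the propyl chain on the shared core.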